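The source may report more compounds than this note shows. Statements on the series, on what has been measured and on what is new or still open speak of the compounds shown alone.

The study turns on a single exchange at one position of two related scaffolds. Compound 2 `CS/C(=N\C(=O)c1cc2ccccc2s1)NC(=O)c1cc2ccccc2s1` was tested in a functional assay on HT-29 cells (Homo sapiens) for cytotoxicity, read by MTT assay, with a stated time of 72 h (a higher number here means that more compound is tolerated, a lower number that less compound is tolerated), where compound 2 gives 88200 nM. Its selenium partner is compound 1 `C[Se]/C(=N\C(=O)c1cc2ccccc2s1)NC(=O)c1cc2ccccc2s1`. In this assay compound 1 reaches only a limit of the assay, > 100000 nM, and no number is reported. The change between them, (a group of 2 heavy atoms (1 carbon, 1 selenium; no ring) in place of a group of 2 heavy atoms (1 carbon, 1 sulfur; no ring), on a carbon with a double bond to nitrogen), therefore amounts to an at least 1.1-fold higher number from compound 2 to compound 1 (0.05 log units; that floor lies within the scatter), and the floor of that step rests on (the limit of > 100000 nM in this assay, at which 2 of the 3 values shown sit).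

On a second core, compound 3 `CS/C(=N\C(=O)c1cc(-c2ccccc2)nc2ccccc12)NC(=O)c1cc(-c2ccccc2)nc2ccccc12` was measured in this assay, and compound 3 likewise reaches only a limit, > 100000 nM. How the core of compound 3 differs from the core of compound 2 is not broken down here.

Compound 4 `C[Se]/C(=N\C(=O)c1cc(-c2ccccc2)nc2ccccc12)NC(=O)c1cc(-c2ccccc2)nc2ccccc12` is not yet measured. It carries the same change as before, (a group of 2 heavy atoms (1 carbon, 1 selenium; no ring) in place of a group of 2 heavy atoms (1 carbon, 1 sulfur; no ring), on a carbon with a double bond to nitrogen), on the same surroundings. Since compound 3 already sits at the limit of this assay, the expected step is a step that the limit leaves unreadable from compound 3 to compound 4, and compound 4 is estimated at 150000 nM, between 60000 nM and 400000 nM.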

Compound 4, concentration lethal to 50% of the cells: 90700 nM
For compound 4 the middle estimate is 1.7-fold (0.22 log units) above the measured one, within the range that was stated.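

In this assay, putting the selenium-bearing group in place of methylsulfanyl on the second core gives an at least 1.1-fold lower number from compound 3 to compound 4 (0.04 log units; that floor lies within the scatter), and this is a floor, not a measured size. Set beside the first core, the two floors point in opposite directions, yet neither separates from the scatter, so no difference between the cores can be claimed: the same change on two cores in this assay, an at least 1.1-fold higher number (0.05 log units; that floor lies within the scatter) from compound 2 to compound 1 and an at least 1.1-fold lower number (0.04 log units; that floor lies within the scatter) from compound 3 to compound 4; the limit leaves it open whether they differ. The series therefore shows neither that the change carries over from one core to the other with the same size nor that it behaves differently there, and each step rests on one value that is only a limit: the limit of > 100000 nM in this assay, at which 2 of the 4 values shown sit.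

The compounds shown leave open how a longer chain carrying the sulfur or selenium would behave at this carbon with a double bond to nitrogen. They also leave open whether an amine or a carboxylic acid on either core would bring both partners of such a pair clear of the limit, so that the step could be read in full.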